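The source may hold more compounds than are shown below. What is called first, only, known or untested is meant among the compounds shown, and "the series" means these compounds.

In a functional assay on A549 cells (Homo sapiens) for inhibition, read by MTT assay, with a stated time of 48 h (on this read-out higher numbers stand for weaker inhibition of growth and lower numbers for stronger inhibition of growth), compound 2 (`Cn1cc(C2CC(c3ccc(Br)cc3)=NN2C(=O)c2cccnc2)c2cc(Br)ccc21`) reports only a limit, > 10000 nM. Compound 1 (`Cn1cc(C2CC(c3ccccc3)=NN2C(=O)c2cccnc2)c2cc(Br)ccc21`) gives 1600 nM. Compound 3 (`COc1cc(C2=NN(C(=O)c3cccnc3)C(c3cn(C)c4ccc(Br)cc34)C2)cc(OC)c1OC`) carries 3,4,5-trimethoxyphenyl in place of 4-bromophenyl on a carbon with a double bond to nitrogen, so 3,4,5-trimethoxyphenyl replaces 4-bromophenyl on a carbon with a double bond to nitrogen. Within the data shown here, the only measured step bearing on this group is an at least 6.2-fold higher number from compound 1 to compound 2 (0.79 log units; beyond the scatter), which came with the bromo in place of hydrogen. With that bromo-bearing group gone, a return to a lower number of similar size is expected, though one measured step is thin support. The expected change in this assay is an at least 3.3-fold lower number from compound 2 to compound 3 (0.52 log units; beyond the scatter). For compound 3 the estimate is 3000 nM, with an expected range of 600 nM to 15000 nM.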

Compound 3, concentration for 50% growth inhibition: > 10000 nM
Compound 3: a limit, no number (the forecaster's own chance of this, stated with the estimate: 30%); at least 3.3-fold (0.52 log units) between middle value and limit.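

In this assay, the 4-bromophenyl group is not the only one at this position to reach the limit: compound 3, with 3,4,5-trimethoxyphenyl on the same carbon with a double bond to nitrogen, also gives only a limit, > 10000 nM. Measured against the phenyl of compound 1, this change is an at least 6.2-fold higher number from compound 1 to compound 3 (0.79 log units; beyond the scatter), so bromo is not the only substituent on this phenyl group that goes with a higher number. The step between compound 2 and compound 3 cannot be read, since both values are limits: the limit of > 10000 nM in this assay, at which 2 of the 3 values shown sit.

Still open, going by these compounds, is whether a methyl group in place of phenyl, or an amine on the phenyl ring, would keep or lower the number of compound 1. On these data alone, the order of compound 2 and compound 3 also remains open.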